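Swapping the benzyl arm for an arylamino group

The compounds below may be only part of what the source reports. "The series", "measured", "known", "first", "only" and "open" are said of these compounds alone.

Compound 3 `Cc1ccc(S(=O)(=O)N(Cc2nnc(Cc3c(Cl)cccc3Cl)o2)c2cccc(Cl)c2C)cc1` is a sulfonamide whose five-membered ring carries a 2,6-dichlorobenzyl arm. In an assay on CHO cells for displacement of a labelled ligand from prostaglandin E2 receptor EP1 subtype (Homo sapiens) (on this read-out lower numbers stand for stronger inhibition and higher numbers for weaker inhibition), compound 3 gives 63.1 nM, the second highest of the three numbers at hand. Its nearest neighbour is compound 1 `Cc1ccc(S(=O)(=O)N(Cc2nnc(Cc3ccc(C(F)(F)F)cc3)o2)c2cccc(Cl)c2C)cc1`, which in this assay gives 50.1 nM; the step of a 1.3-fold higher number from compound 1 to compound 3 (0.10 log units; within the scatter) lies within the scatter. Furthest away is compound 2 `Cc1ccc(S(=O)(=O)N(Cc2nnc(Cc3ccccc3F)o2)c2cccc(Cl)c2C)cc1`, which gives 501 nM; the step of a 7.9-fold lower number from compound 2 to compound 3 (0.90 log units; beyond the scatter) is beyond the scatter, as is a 10-fold higher number from compound 1 to compound 2 (1.00 log units; beyond the scatter).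

Compound 4 `COc1ccc(Nc2nnc(CN(c3cccc(Cl)c3C)S(=O)(=O)c3ccc(C)cc3)o2)cc1` differs from compound 3 by (4-methoxyphenyl)amino in place of 2,6-dichlorobenzyl on an aromatic carbon. Among the compounds with values here, none of the measured steps bears directly on this change: all three vary only the aryl group on the saturated chain carbon, whereas here the chain carbon itself is lost and an amino linker enters. Those aryl variations moved this assay by up to the size of a 10-fold higher number from compound 1 to compound 2 (1.00 log units; beyond the scatter), so a shift of a similar order in either direction is plausible, and a worsening is taken as somewhat more likely for compound 4, with the step of a 3.2-fold higher number from compound 3 to compound 4 (0.50 log units; beyond the scatter) expected. Compound 4 is therefore estimated at 200 nM in this assay, with a range from 40 nM to 1500 nM.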

Compound 4, half-maximal inhibitory concentration: 31.6 nM
For compound 4 the middle estimate is 6.3-fold (0.80 log units) above the measured one; measured number outside the range, below it.
By their numbers in this assay, from the lowest: compounds 4, 1 and 3 (each within the scatter of the next); then compound 2.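

The aromatic carbon of the five-membered ring accepts more than a benzyl arm: with the saturated chain carbon gone and an amino linker bearing a 4-methoxyphenyl group in its place, this assay gives a 2.0-fold lower number from compound 3 to compound 4 (0.30 log units; within the scatter) and a 1.6-fold lower number from compound 1 to compound 4 (0.20 log units; within the scatter), both within the scatter. So this change, which brings in nitrogen, oxygen and a hydrogen-bond donor, leaves compound 4 level with the two better benzyl compounds, while the only step beyond the scatter is a 16-fold lower number from compound 2 to compound 4 (1.20 log units; beyond the scatter), which sets it apart from the 2-fluorobenzyl arm alone. Nothing at hand accounts for this result.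

The amino linker and the 4-methoxyphenyl group arrive together in compound 4, so what each contributes on its own cannot be read from these compounds, and a (2,6-dichlorophenyl)amino or (4-(trifluoromethyl)phenyl)amino group would be needed to separate them. Also open, from the compounds shown here alone, is whether the linker's hydrogen matters, which an N-methylamino linker or an ether oxygen in the same place would address.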